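Half-life expected from 3-hydroxycyclobutyl on the aromatic nitrogen

The source may hold more compounds than are shown below. What is called first, only, known or untested is meant among the compounds shown, and "the series" means these compounds.

Measured in an ADME assay on microsomes from liver (Mus musculus) for metabolic stability, read by LC-MS, using NADPH, with a stated time of 10 min, tested at 10 uM; a lower number here means that the compound disappears faster, a higher number that the compound lasts longer:
compound 1 `N#Cc1ccnc(Oc2nn(C3CCC3)c3ncnc(N)c23)c1`: 0.4 h
compound 2 `N#Cc1ccnc(Oc2nn([C@H]3C[C@H](O)C3)c3ncnc(N)c23)c1`: > 2.41 h (a limit)
compound 3 `N#Cc1ccnc(Oc2nn(C3CC3)c3ncnc(N)c23)c1`: > 2.41 h (a limit)

Compound 3 has no exact number and sits at the limit of > 2.41 h in this assay, at which 2 of the 3 values shown sit. Compound 4 `N#Cc1ccnc(Oc2nn([C@H]3C[C@@H](O)C3)c3ncnc(N)c23)c1` carries 3-hydroxycyclobutyl in place of cyclopropyl on an aromatic nitrogen. Hydroxy in place of hydrogen on a saturated ring carbon gave an at least 6.0-fold higher number from compound 1 to compound 2 (0.77 log units; beyond the scatter). Cyclopropyl in place of cyclobutyl gave an at least 6.0-fold higher number from compound 1 to compound 3 (0.77 log units; beyond the scatter). Compound 2 also carries 3-hydroxycyclobutyl, and the closest comparison is a step that the two limits leave unreadable from compound 2 to compound 3. No step beyond the scatter is therefore expected in this assay, and the estimate is a step that the limit leaves unreadable from compound 3 to compound 4. For compound 4 the estimated half-life is 2.5 h, with an expected range of 1 h to 6 h.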

Compound 4, half-life: > 2.41 h
Compound 4: a limit, no number; the forecaster's own chance of this, stated with the estimate: 65%; the middle value lies beyond the limit too.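

In this assay, hydroxy in place of hydrogen on a saturated ring carbon gives an at least 6.0-fold higher number from compound 1 to compound 4 (0.77 log units; beyond the scatter). The step from compound 1 to compound 2 is of the same kind, so at this place on the aromatic nitrogen the change holds for both configurations: the fact that compounds 2 and 4 differ only in the configuration as drawn. Compound 4 gives a limit, not a number, and the steps linking compound 2, compound 3 and compound 4 cannot be read: the limit of > 2.41 h in this assay, at which 3 of the 4 values shown sit.

As far as these compounds go, whether the two configurations differ in this assay stays open. So does the outcome with an amine or a carboxylic acid in place of the hydroxy on the four-membered ring.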